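This account rests on a few compounds, and the source may have more. Where it says the series, first, only, none or still open, it means among the compounds named here.

Measured so far:
Compound 1, `O=C(Nc1nnc(-c2ccc(Cl)cc2)s1)c1ccccc1I`, in a functional assay on the whole organism (integument) for inhibition, with Chilo suppressalis as the target, read by scintillation counting, with a stated time of 72 h (a higher number here means a weaker inhibitor, a lower number a stronger inhibitor), gives > 5010 nM, which is a limit of the assay rather than a number.
Compound 2, `COc1ccccc1C(=O)Nc1nnc(-c2ccc(Cl)cc2)s1`, in this assay gives 53.7 nM.
Compound 3, `COc1cccc(OC)c1C(=O)Nc1nnc(-c2ccc(C(C)C)cc2)s1`, in this assay gives 398 nM.

Among the two numbers, compound 3 stands highest, and compound 2, the nearer one, shows the lower number. Compound 4, `CCN(CC)c1ccc(-c2nnc(NC(=O)c3c(OC)cccc3OC)s2)cc1`, differs from compound 3 in one place: diethylamino in place of isopropyl on an aromatic carbon. Among the measured compounds shown here, the only measured step, an at least 93-fold lower number from compound 1 to compound 2 (1.96 log units; beyond the scatter), concerns another part of the molecule and another pair of groups, so it does not bear on this change; the one limit, (the limit of > 5010 nM in this assay, at which 1 of the 3 values shown sits), belongs to that same step. With nothing measured at this place, no change beyond the scatter is expected, and the step of a 1.3-fold lower number from compound 3 to compound 4 (0.12 log units; within the scatter) is estimated to be small. Compound 4 is therefore expected to give about 300 nM, between 80 nM and 1500 nM.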

Compound 4, half-maximal inhibitory concentration: 741 nM
The estimate for compound 4 lay 2.5-fold (0.39 log units) below the measured number, and the stated range covers the measured number.
By their numbers in this assay, from the lowest: compound 2; then compounds 3 and 4 (each within the scatter of the next). At a limit, above all of these: compound 1.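

In this assay, the change at this aromatic carbon gives a 1.9-fold higher number from compound 3 to compound 4 (0.27 log units; within the scatter). Among the compounds shown here, the swap of isopropyl for diethylamino, which adds heavy atoms and a hydrogen-bond acceptor, therefore moves the number no more than repeat measurements would, something the earlier compounds, with no step at this place, could not show. Nothing measured here offers a reason for this result. On these data alone, whether a primary amine or a carboxylic acid on this carbon would also leave the number within the scatter stays open.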